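The compounds below may be only part of what the source reports. "The series", "measured", "known", "first", "only" and "open" are said of these compounds alone.

Among the measured compounds shown here, in a functional assay on MCF7 cells (Homo sapiens) for antiproliferative activity, read by MTT assay, with a stated time of 48 h (a lower number here means a stronger inhibitor, a higher number a weaker inhibitor), three compounds built on a shared core have numbers so far. Compound 3 (`C#Cc1cccc(Nc2ncnc3sc(NC(=O)/C=C/c4ccccc4)cc23)c1`) gives 38400 nM as its reading. Compound 1 (`COc1ccc(/C=C/C(=O)Nc2cc3c(Nc4cc(Cl)cc(Cl)c4)ncnc3s2)cc1`) gives 75600 nM and sits within the usual scatter of compound 3. For the measured compounds named here, compound 2 (`O=C(/C=C/c1ccccc1)Nc1cc2c(Nc3cccc(Cl)c3F)ncnc2s1`) gives 93900 nM and is the only one clearly apart from compound 3.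

Compound 4 (`O=C(/C=C/c1ccccc1)Nc1cc2c(Nc3cc(Cl)cc(Cl)c3)ncnc2s1`) is still unmeasured. It carries 3,5-dichlorophenyl in place of 3-ethynylphenyl on a nitrogen on an aromatic ring and is otherwise the same as compound 3.

Going by the values given here, one measured step bears directly on this swap: putting 3-ethynylphenyl in place of 3-chloro-2-fluorophenyl gave a 2.4-fold lower number from compound 2 to compound 3 (0.39 log units; beyond the scatter) and was modest, just beyond the scatter. Compound 4 again trades between the ethynyl group and a chlorine-bearing ring, this time in the opposite direction, so this assay is expected to show a step of similar or smaller size towards a higher number. Compound 1 at 75600 nM offers only loose support, as it holds the same 3,5-dichlorophenyl group but also a methoxy group that compound 4 lacks.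

The estimated step is a 1.8-fold higher number from compound 3 to compound 4 (0.26 log units; within the scatter) and it stays close to the edge of the scatter. For compound 4 the expected value is 70000 nM with an estimated range of 35000 nM to 140000 nM in this measurement.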

Compound 4, half-maximal inhibitory concentration: 5800 nM
Beside the measured number, compound 4's estimate is 12-fold (1.08 log units) above it; the whole stated range lies above it.
By their numbers in this assay, from the lowest: compound 4; then compounds 3, 1 and 2 (each within the scatter of the next, the first and the last beyond it).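

In this assay, among the compounds shown here, the group on the nitrogen proves able to move the number much further than the earlier compounds showed: 3,5-dichlorophenyl in place of 3-ethynylphenyl gives a 6.6-fold lower number from compound 3 to compound 4 (0.82 log units; beyond the scatter), a larger step than a 2.4-fold lower number from compound 2 to compound 3 (0.39 log units; beyond the scatter) seen before. Carrying chlorine does not by itself decide the outcome, since 3,5-dichlorophenyl in place of 3-chloro-2-fluorophenyl gives a 16-fold lower number from compound 2 to compound 4 (1.21 log units; beyond the scatter), which leaves the two chlorine-bearing rings of compound 2 and compound 4 on opposite sides of the ethynyl compound. With 3,5-dichlorophenyl held constant, hydrogen in place of methoxy on an aromatic carbon gives a 13-fold lower number from compound 1 to compound 4 (1.12 log units; beyond the scatter), so this second site also matters, although no measurement here explains why any of these steps occur.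

The compounds shown leave open whether both chlorines are required, which a ring with a single chlorine, or with two bromines in their place, could test. They also leave open whether this step is particular to methoxy, which a fluorine or a dimethylamino group on that same aromatic carbon could help to settle.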